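The compounds below may be only part of what the source reports. "The series", "measured", "known", "first", "only" and "open" are said of these compounds alone.

Working notes on the series. Compound 1 `BrCCCCCCOc1c(Br)cc(Br)cc1Oc1ccc(Br)cc1Br` in a functional assay on HL-60 cells (Homo sapiens) for cytotoxicity, read by MTT assay, with a stated time of 24 h (a lower number here means a stronger inhibitor, a higher number a weaker inhibitor), gives 37.8 ug/mL. Compound 2 `COc1c(Br)cc(Br)cc1Oc1ccc(Br)cc1Br` gives 28.2 ug/mL in this assay, and compound 3 `CC(C)(C)C(=O)C(C#N)Oc1c(Br)cc(Br)cc1Oc1ccc(Br)cc1Br` gives 29.2 ug/mL in this assay. The three values lie within the scatter of one another, so no order among them can be read: a 1.3-fold lower number from compound 1 to compound 2 (0.13 log units; within the scatter), a 1.3-fold lower number from compound 1 to compound 3 (0.11 log units; within the scatter) and a 1.0-fold higher number from compound 2 to compound 3 (0.02 log units; within the scatter) are each within the scatter. Compound 3 thus sits closest to compound 2 and somewhat further from compound 1, with no gap that exceeds the scatter.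

Compound 4 `C#CCOc1c(Br)cc(Br)cc1Oc1ccc(Br)cc1Br` has not yet been measured. It differs from compound 3 in one place: propargyl in place of cyano((tert-butyl)carbonyl)methyl on an oxygen on an aromatic ring. For the measured compounds named here, the steps that bear on this exchange are those that also swap the group on the same oxygen, namely a 1.0-fold higher number from compound 2 to compound 3 (0.02 log units; within the scatter) and a 1.3-fold lower number from compound 1 to compound 3 (0.11 log units; within the scatter), together with the related 1.3-fold lower number from compound 1 to compound 2 (0.13 log units; within the scatter). None of these three exchanges moved the number in this assay beyond the scatter, even though the groups exchanged differ widely in size. For compound 4 the expectation is therefore a step of a 1.0-fold lower number from compound 3 to compound 4 (0.00 log units; within the scatter), none beyond the scatter. Compound 4 is estimated at 29 ug/mL in this assay, with a range from 15 ug/mL to 56 ug/mL.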

Compound 4, half-maximal inhibitory concentration: 29.7 ug/mL
Beside the measured number, compound 4's estimate is 1.0-fold (0.01 log units) below it; the range from low to high includes it.
By their numbers in this assay, from the lowest: compounds 2, 3, 4 and 1 (each within the scatter of the next).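

For the compounds shown here, exchanging cyano((tert-butyl)carbonyl)methyl for propargyl on this oxygen on an aromatic ring gives a 1.0-fold higher number from compound 3 to compound 4 (0.01 log units; within the scatter) in this assay, so a group with 0 hydrogen-bond acceptors and no nitrile or carbonyl reads the same as one with 2 hydrogen-bond acceptors, a variation in the group's make-up that the earlier steps did not isolate. The same holds for the triple bond of propargyl against the methyl and 6-bromohexyl groups, with a 1.1-fold higher number from compound 2 to compound 4 (0.02 log units; within the scatter) and a 1.3-fold lower number from compound 1 to compound 4 (0.10 log units; within the scatter), so all four groups on this oxygen now fall within the scatter of one another and none of the steps separates them. No measurement bears on why the number stays flat across these groups.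

As far as these compounds go, all the groups on this oxygen so far carry no net charge, so it remains open whether an amine or a carboxylic acid there would give a step beyond the scatter. From the compounds shown here alone, it is also open how much of the number comes from the shared core, since every compound keeps that core unchanged and a free hydroxyl on this oxygen would be needed as a further point of comparison.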